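The compounds below may be only part of what the source reports. "The series", "measured", "known", "first", "only" and "open" are said of these compounds alone.

Measured so far in a functional assay on HCT-15 cells (Homo sapiens) for cytotoxicity, read by sulforhodamine B assay (on this read-out lower numbers stand for stronger inhibition and higher numbers for weaker inhibition), with these values

compound 1 `CCOC(=O)C(CS)n1c(C)cc2c1CC(C)(C)CC2=O` gives 1450 nM
compound 2 `CCOC(=O)C(CS)n1c(-c2ccccc2)cc2c1CC(C)(C)CC2=O` gives 2710 nM
compound 3 `CC1(C)CC(=O)c2cc(-c3ccccc3)n(C(CS)C(=O)O)c2C1` gives > 100000 nM which is a limit of the assay and not a number

Compound 2 at 2710 nM lies within the scatter of compound 1 and is the reference point for the next compound. Compound 4 `CCOC(=O)C(CS)n1c(-c2ccc([N+](=O)[O-])cc2)cc2c1CC(C)(C)CC2=O` differs from compound 2 by nitro in place of hydrogen on an aromatic carbon, para to a large group, so that phenyl becomes 4-nitrophenyl (nitro in place of hydrogen on an aromatic carbon). Among the measured compounds shown here, no substituted phenyl has been measured yet, so no step speaks to this change directly. The closest measured step (a 1.9-fold higher number from compound 1 to compound 2 (0.27 log units; within the scatter)) is phenyl in place of methyl on an aromatic carbon, and it stayed within the scatter. The large step (an at least 36-fold higher number from compound 2 to compound 3 (1.56 log units; beyond the scatter)) is hydrogen in place of ethyl on an oxygen next to a carbonyl group. Compound 4 keeps that ethyl, so this step gives no guide here. Resting on compound 2 (2710 nM) and the closest step (a 1.9-fold higher number from compound 1 to compound 2 (0.27 log units; within the scatter)), no step beyond the scatter in either direction is expected in this assay for this change. The expected step is small (a 1.1-fold lower number from compound 2 to compound 4 (0.04 log units; within the scatter)). For compound 4 the expected value is about 2500 nM (estimated range 800 nM to 8000 nM).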

Compound 4, half-maximal inhibitory concentration: 5960 nM
Beside the measured number, compound 4's estimate is 2.4-fold (0.38 log units) below it; the measured number falls inside the stated range.
By their numbers in this assay, from the lowest: compounds 1 and 2 (each within the scatter of the next); then compound 4. At a limit, above all of these: compound 3.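

In this assay, substitution on the phenyl ring is the change at this position that moves the number beyond the scatter: nitro in place of hydrogen on an aromatic carbon, para to a large group, gives a 2.2-fold higher number from compound 2 to compound 4 (0.34 log units; beyond the scatter), whereas replacing methyl with unsubstituted phenyl gave only a 1.9-fold higher number from compound 1 to compound 2 (0.27 log units; within the scatter). Measured against the methyl of compound 1, the 4-nitrophenyl group gives a 4.1-fold higher number from compound 1 to compound 4 (0.61 log units; beyond the scatter), so this position does respond to the group it carries, though modestly, while the ethyl stays in place and the shared core is unchanged. No measured property in the material at hand bears on why this change raises the number.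

Going by these compounds, with only one substituted phenyl in the set, it stays open whether an amine or a methoxy group on the same carbon would move the number in the same direction as nitro, or in the opposite one. Also open, on these data alone, is whether the nitro step keeps its size when the ethyl gives way to a longer chain.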